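Trimethylpyrazinylmethyl ether in place of hydroxy on a second core

This account rests on a few compounds, and the source may have more. Where it says the series, first, only, none or still open, it means among the compounds named here.

Measured so far in a functional assay on SH-SY5Y cells (Homo sapiens) for cytotoxicity, read by MTT assay, with stated times of 24 h and 4 h; on this read-out lower numbers stand for an effect already at smaller amounts and higher numbers for an effect only at larger amounts of compound:
compound 1, `COc1cc(CNC(=O)/C=C/c2cc(OC)c(OC)c(OC)c2)ccc1O`, gives 5910 nM
compound 2, `COc1cc(CNC(=O)/C=C/c2cc(OC)c(OC)c(OC)c2)ccc1OCc1nc(C)c(C)nc1C`, gives 11500 nM
compound 3, `COc1cc(CNC(=O)/C=C/c2ccc(OC)c(OC)c2OC)ccc1O`, gives 7450 nM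

Compound 2 differs from compound 1 by one change, ((3,5,6-trimethylpyrazin-2-yl)methyl in place of hydrogen on an oxygen on an aromatic ring), and the step read a 1.9-fold higher number from compound 1 to compound 2 (0.29 log units; within the scatter). Compound 3 is built from the same atoms as compound 1, joined differently; the difference between the two cores is not broken down here. Compound 3 and compound 1 give values that lie within the scatter of each other in this assay, so no order between them is claimed.

Compound 4, `COc1cc(CNC(=O)/C=C/c2ccc(OC)c(OC)c2OC)ccc1OCc1nc(C)c(C)nc1C`, is the counterpart of compound 2 on the core of compound 3: (3,5,6-trimethylpyrazin-2-yl)methyl in place of hydrogen on an oxygen on an aromatic ring. The place of the change reads the same in both pairs, so it is the same change, seen here for the second time.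

The step from compound 3 to compound 4 is expected to be about a 1.7-fold higher number from compound 3 to compound 4 (0.24 log units; within the scatter), because the same change gave a 1.9-fold higher number from compound 1 to compound 2 (0.29 log units; within the scatter). Compound 4 is therefore estimated at 13000 nM, with the likely range 6500 nM to 26000 nM.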

Compound 4, half-maximal effective concentration: 3840 nM
Compound 4: the middle estimate sits 3.4-fold (0.53 log units) above what was measured; measured number below the stated range.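

In this assay, the change from hydroxy to (3,5,6-trimethylpyrazin-2-yl)methoxy does not carry from one core to the other as a fixed step: the same change on two cores in this assay, a 1.9-fold higher number (0.29 log units; within the scatter) from compound 1 to compound 2 and a 1.9-fold lower number (0.29 log units; within the scatter) from compound 3 to compound 4, 3.8-fold (0.58 log units) apart, beyond the scatter of two such steps. Taken alone, the new step, a 1.9-fold lower number from compound 3 to compound 4 (0.29 log units; within the scatter), shows no effect of the change on the core of compound 3, and only the gap between the two steps lies beyond the scatter. With the ether in place, 2,3,4-trimethoxyphenyl in place of 3,4,5-trimethoxyphenyl gives a 3.0-fold lower number from compound 2 to compound 4 (0.48 log units; beyond the scatter), but two pairs do not show why the steps differ or how the change would read on any further core.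

Going by these compounds, it remains open whether the gap between the steps recurs on other cores. Also open, on these data alone, is whether a plain methyl or benzyl group, or a chain ending in an amine, on the same oxygen would read like the trimethylpyrazinylmethyl group on either core.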